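Cytotoxicity notes on three measured analogues and one pending

The source may hold more compounds than are shown below. What is called first, only, known or untested is meant among the compounds shown, and "the series" means these compounds.

Measured so far:
- compound 1 `O=C(c1ccc2c(c1)OCCO2)C1CCN(Cc2coc(-c3ccccc3)n2)CC1`: in an ADME assay on HEK293 cells (Homo sapiens) for cytotoxicity, read by MTT assay, with a stated time of 36 h (on this read-out higher numbers stand for weaker inhibition and lower numbers for stronger inhibition), compound 1 gives only a limit of the assay, > 150 ug/mL.
- compound 2 `Cc1ccc(-c2nc(CN3CCC(C(=O)c4ccc5c(c4)OCCO5)CC3)co2)cc1`: in this assay compound 2 gives only a limit of the assay, > 150 ug/mL.
- compound 3 `Cc1ccc(C(=O)C2CCN(Cc3coc(-c4ccc(F)cc4)n3)CC2)cc1C`: in this assay compound 3 gives only a limit of the assay, > 150 ug/mL.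

Compound 2 and compound 1 differ by hydrogen in place of methyl on an aromatic carbon; the two limits leave the step that the two limits leave unreadable from compound 2 to compound 1 unreadable. All that is known is the limit of > 150 ug/mL in this assay, at which 3 of the 3 values shown sit. How the core of compound 3 differs from the core of compound 2 is not broken down here.

Compound 4 `Cc1ccc(C(=O)C2CCN(Cc3coc(-c4ccc(F)cc4)n3)CC2)cc1` is not yet measured. It differs from compound 3 by hydrogen in place of methyl on an aromatic carbon. The surroundings are not identical to the earlier pair: there the place was para to a large group, here it is ortho to a methyl group and meta to a large group, so this is the same kind of change, not the same change. For compound 4 a step of a number no higher from compound 3 to compound 4 (the limit leaves the size open) is expected, resting on compound 3 sitting at > 150 ug/mL and on (the limit of > 150 ug/mL in this assay, at which 3 of the 3 values shown sit). Compound 4 is therefore estimated at 150 ug/mL, between 75 ug/mL and 300 ug/mL, most likely again reported only as a limit.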

Compound 4, half-maximal inhibitory concentration: > 150 ug/mL
Compound 4 gave a limit, no number; the forecaster's own chance of this, stated with the estimate: 85%; the middle value lies on the limit itself.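

For the compounds shown here, compound 3 and compound 4 both give only a limit in this assay, so no step between them can be read. Going by these compounds alone, the series so far shows one result: the limit of > 150 ug/mL in this assay, at which 4 of the 4 values shown sit. The compounds shown leave open how large the step from 3,4-dimethylphenyl to 4-methylphenyl is, and whether any analogue gives a readable number in this assay.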